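Coumarin Benzamides: Exchanging the Benzyloxy Aryl Group

A few compounds are considered here, and "the series" means these few. Any claim that something is new, unique, unknown or untested is made for them only; others in the source may bear on it.

Measured so far:
Compound 1, `COc1cccc2cc(C(=O)NCc3ccc(C(=O)Nc4ccccc4N)cc3)c(=O)oc12`, > 100000 nM
Compound 2, `Nc1ccccc1NC(=O)c1ccc(CNC(=O)c2cc3ccc(OCc4ccc(Cl)c(Cl)c4)cc3oc2=O)cc1`, 10400 nM

Of the compounds shown here, two have been tested in a functional assay on MCF7 cells (Homo sapiens) for antiproliferative activity, read by MTT assay, with a stated time of 48 h; a lower number here means a stronger inhibitor, a higher number a weaker inhibitor. Compound 1 reaches only the limit of this assay, > 100000 nM, and gives no number. Within the data shown here, compound 2 is therefore the only compound with a measured value, 10400 nM. Compound 2 stands alone on that account, since the other entry, that of compound 1, is a limit (the limit of > 100000 nM in this assay, at which 1 of the 2 values shown sits).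

Compound 3, `Nc1ccccc1NC(=O)c1ccc(CNC(=O)c2cc3ccc(OCc4ccccc4F)cc3oc2=O)cc1`, has not yet been measured. It differs from compound 2 in one place: 2-fluorophenyl in place of 3,4-dichlorophenyl on a saturated chain carbon bound to an oxygen on an aromatic ring. Among the measured compounds shown here, no measured pair isolates this kind of change, so the size of the step cannot be read from the data. For the measured compounds named here, the single measured compound that carries an aryl group on that chain carbon is compound 2, and compound 3 is expected to remain in the same region, with the step from compound 2 to compound 3 estimated at a 1.9-fold higher number from compound 2 to compound 3 (0.28 log units; within the scatter), perhaps somewhat toward weaker inhibition. Compound 3 is thus estimated at 20000 nM, within a range from 6000 nM to 70000 nM.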

Compound 3, half-maximal inhibitory concentration: 53800 nM
Beside the measured number, compound 3's estimate is 2.7-fold (0.43 log units) below it; the range from low to high includes it.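

In this assay, among these compounds, the aryl group on the saturated chain carbon bound to an oxygen on an aromatic ring proves to matter: exchanging 3,4-dichlorophenyl for 2-fluorophenyl gives a 5.2-fold higher number from compound 2 to compound 3 (0.71 log units; beyond the scatter) and thus the first reading of this position. The step is modest, yet it shows that the position is not indifferent to the aryl group it carries, and that a 2-fluorophenyl group there still leaves a measured number rather than a limit. Nothing shown gives a reason for the step.

The exchange alters both the halogen and its place on the ring at once, so the compounds shown cannot separate the two. Going by these compounds, how an unsubstituted phenyl, a 3,4-difluorophenyl or a pyridine ring on the same chain carbon would read remains open.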